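Adding a Carboxy Group to the Biphenyl Tail of Compound 1

The compounds below may be only part of what the source reports. "The series", "measured", "known", "first", "only" and "open" are said of these compounds alone.

Compound 1 `Cc1ccccc1-n1nc(C)c2c1NC(=O)[C@H](C)S[C@@H]2c1ccc(-c2ccccc2)cc1` sits at the lowest of the three numbers in an assay on isolated protein for agonist activity at Bile acid receptor (Homo sapiens), read by AlphaScreen, with a stated time of 30 min (a higher number here means that more compound is needed for the effect, a lower number that less compound is needed), where compound 1 gives 990 nM. Compound 3 `Cc1nn(-c2ccccc2I)c2c1C(c1ccc(Oc3ccccc3)cc1)SC(C)C(=O)N2` gives 1300 nM in this assay, a value within the scatter of compound 1, while compound 2 `Cc1nn(-c2ccccc2C(F)(F)F)c2c1C(c1ccc(Oc3ccccc3)cc1)SC(C)C(=O)N2` gives 2000 nM, a higher number beyond the scatter. Within the data shown here, the one measured step, a 1.5-fold lower number from compound 2 to compound 3 (0.19 log units; within the scatter), concerns a different ring and does not bear on the change examined here. Compound 4 `Cc1ccccc1-n1nc(C)c2c1NC(=O)[C@H](C)S[C@@H]2c1ccc(-c2ccc(C(=O)O)cc2)cc1` differs from compound 1 by carboxy in place of hydrogen on an aromatic carbon. Among the measured compounds shown here, no measured step speaks to this change, so the expected direction is uncertain; compound 4 is estimated at 600 nM, between 150 nM and 2500 nM, an expected step of a 1.7-fold lower number from compound 1 to compound 4 (0.22 log units; within the scatter).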

Compound 4, half-maximal effective concentration: "not active" (no number reported)
Compound 4 has no reported number here, so the estimate cannot be set against anything.
By their numbers in this assay, from the lowest: compounds 1, 3 and 2 (each within the scatter of the next, the first and the last beyond it).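

Among these compounds, compound 4 is reported as "not active" with no number, so no step from compound 1 to compound 4 can be read. Nothing at hand explains this result. The compounds shown leave open whether another group in place of that hydrogen of compound 1 would give a number in this assay at all.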